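The source may hold more compounds than are shown below. What is called first, only, known or untested is meant among the compounds shown, and "the series" means these compounds.

Measured compounds:
compound 1 `CC(NC(=O)NS(=O)(=O)c1ccc(Cl)cc1)c1cc(Br)ccc1OCc1ccccc1` with 57500 nM
compound 2 `CC(NC(=O)NS(=O)(=O)c1ccccc1)c1cc(Br)ccc1OCc1ccccc1` with 130000 nM
compound 3 `COc1ccc(Br)cc1C(C)NC(=O)N(C)S(=O)(=O)c1ccccc1` with 16800 nM

The three compounds were tested in a functional assay on thoracic aorta (Rattus norvegicus, strain Wistar), with a stated time of 15 min; on this read-out higher numbers stand for an effect only at larger amounts of compound and lower numbers for an effect already at smaller amounts. Compound 2 gives the highest number of the three, and compound 1, which differs from it only by chloro in place of hydrogen on an aromatic carbon, gives a number that is lower: a 2.3-fold lower number from compound 2 to compound 1 (0.35 log units; beyond the scatter). Compound 3 gives the lowest number of the three; it is built on a different core, and the difference between its core and that of compound 2 is not broken down here.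

Compound 4 `COc1ccc(Br)cc1C(C)NC(=O)N(C)S(=O)(=O)c1ccc(Cl)cc1` has not been measured. It differs from compound 3 by chloro in place of hydrogen on an aromatic carbon, the same change that turns compound 2 into compound 1, at the same kind of place: on an aromatic carbon of a six-membered aromatic ring of carbon only, para to a large group. That change occurs only twice among the compounds shown, once measured and once not, so the expectation for compound 4 rests on a single step. Because the step of a 2.3-fold lower number from compound 2 to compound 1 (0.35 log units; beyond the scatter) is modest but beyond the scatter, compound 4 is expected to give a lower number than compound 3 by a similar margin, a 2.1-fold lower number from compound 3 to compound 4 (0.32 log units; beyond the scatter), though the different core leaves room for the step to come out smaller or larger. The estimate for compound 4 in this assay is therefore 8000 nM, with a likely range from 3000 nM to 20000 nM.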

Compound 4, half-maximal effective concentration: 19100 nM
Compound 4: middle estimate off by 2.4-fold (0.38 log units), on the low side, and the stated range covers the measured number.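

In this assay, the change from phenyl to 4-chlorophenyl gave a 1.1-fold higher number from compound 3 to compound 4 (0.06 log units; within the scatter), so compound 3 and compound 4 cannot be told apart on this core. The other core gave a modest step beyond the scatter, a 2.3-fold lower number from compound 2 to compound 1 (0.35 log units; beyond the scatter), but the gap between this step and the new one is not large enough to show that the two cores respond differently: the same change on two cores in this assay, a 2.3-fold lower number (0.35 log units; beyond the scatter) from compound 2 to compound 1 and a 1.1-fold higher number (0.06 log units; within the scatter) from compound 3 to compound 4, 2.6-fold (0.41 log units) apart, within the scatter of two such steps. Among the compounds shown here, the result therefore does not show that the lower number seen on the first core carries over to the second, nor does it establish that the core changes the effect of chloro, and with only one pair on each core, a true dependence on the core cannot be separated from ordinary scatter.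

The compounds shown leave open what each part of the difference between the two cores contributes on its own, as no pair here differs in just one part of it. They also leave open whether a group other than chloro at the same place, such as a methoxy group, an amine or a carboxylic acid, would give a step beyond the scatter on either core.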